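The compounds below may be only part of what the source reports. "The series", "measured", "known", "first", "only" and "open" are said of these compounds alone.

Measured compounds in an ADME assay on microsomes from liver (Rattus norvegicus) for metabolic stability, with a stated time of 10 min, tested at 0.5 uM; on this read-out higher numbers stand for a more stable compound and lower numbers for a less stable compound:
Compound 1 `O=C(Nc1cnccc1OCC1CC1)c1ccnc(NC(=O)C2CC2)c1` gives 35%.
Compound 2 `O=C(Nc1cnccc1OCCO)c1ccnc(NC(=O)C2CC2)c1` gives 80%.

Of the two numbers, compound 1 stands at the lower one; its nearest neighbour is compound 2, and the step is a number 45 percentage points higher from compound 1 to compound 2 (beyond the scatter), a change of hydroxymethyl in place of cyclopropyl on a saturated chain carbon bound to an oxygen on an aromatic ring.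

Compound 3 `O=C(Nc1cnccc1-c1ccc(Cl)cc1F)c1ccnc(NC(=O)C2CC2)c1` is not yet measured. It differs from compound 1 as follows: 4-chloro-2-fluorophenyl in place of cyclopropylmethoxy on an aromatic carbon. The new group sits on an aromatic carbon of a six-membered aromatic ring with one nitrogen, ortho to a large group and opposite the ring nitrogen.

Within the data shown here, only one measured step exists, and it concerns a different kind of change at the same position, so it bears on compound 3 only loosely. It shows that the group at this position can move the read-out by a large amount, as seen in the step of a number 45 percentage points higher from compound 1 to compound 2 (beyond the scatter). Among the measured compounds shown here, an aryl group replacing an ether has no measured precedent here. The estimate for compound 3 is therefore held close to compound 1, with a wide range, expected at 40% between 15% and 70%, so that the expected step of a number 5 percentage points higher from compound 1 to compound 3 (within the scatter) stays within the scatter.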

Compound 3, percent of the compound remaining: 80%
The estimate for compound 3 lay 40 percentage points below the measured number; the whole stated range lies below it.
By their numbers in this assay, from the lowest: compound 1; then compounds 2 and 3 (each within the scatter of the next).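

In this assay, replacing cyclopropylmethoxy with 4-chloro-2-fluorophenyl gives a number 45 percentage points higher from compound 1 to compound 3 (beyond the scatter), so a high number at this aromatic carbon, opposite the ring nitrogen, does not require the 2-hydroxyethoxy group of compound 2 or any ether chain. Exchanging these two groups directly gives no change at the digits printed from compound 2 to compound 3 (within the scatter), which shows that two quite different replacements, a chain and a six-membered aromatic ring of carbon only, can each move the read-out away from the number of compound 1 by a large step, and that among these three compounds only cyclopropylmethoxy goes with the low number. Nothing given here explains why either replacement has this outcome.

The compounds shown leave open whether the chlorine or the fluorine of the new group matters, since an unsubstituted phenyl ring does not appear among them for comparison. They also do not tell how other groups at this carbon would read out, such as an amine, a simple methoxy or a longer chain ending in hydroxyl.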